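One Chloro Fewer: Expecting a Modest Solubility Gain

The source may report more compounds than this note shows. Statements on the series, on what has been measured and on what is new or still open speak of the compounds shown alone.

Two measured compounds share the same core and differ only in what sits on one aromatic ring. In a physicochemical assay for solubility, at pH 7.4 (a higher number here means a more soluble compound, a lower number a less soluble compound), compound 1 `Cc1cc(NC(=O)Nc2ccccc2OC(F)(F)F)c2ccccc2n1` gives 4600 nM. In this assay compound 2 `Cc1cc(NC(=O)Nc2ccc(Cl)c(Cl)c2)c2ccccc2n1` gives 300 nM, the lowest of the two numbers on record, and the gap from compound 1 to compound 2 is well beyond the usual scatter of repeated measurements.

Compound 3 `Cc1cc(NC(=O)Nc2cccc(Cl)c2)c2ccccc2n1` has not yet been measured. It differs from compound 2 in a single place, where (hydrogen in place of chloro on an aromatic carbon). One chlorine leaves and nothing heavier than a hydrogen enters, so compound 3 is a slightly smaller molecule than compound 2 and otherwise identical.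

Going by the values given here, no measured pair shows this particular change, so the size of the step is uncertain. With one heavy atom leaving, compound 3 is expected to become more soluble than compound 2, by a moderate step of a 3.3-fold higher number from compound 2 to compound 3 (0.52 log units; beyond the scatter) rather than a dramatic one. In this assay compound 3 is therefore estimated at 1000 nM, with a plausible range from 300 nM to 3500 nM.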

Compound 3, solubility: 800 nM
Estimate against measurement, compound 3: 1.3-fold (0.10 log units) above, and the stated range covers the measured number.
By their numbers in this assay, from the lowest: compound 2; then compound 3; then compound 1.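

Compound 1 and compound 2 differ in more than one place on their aromatic ring, so the gap between them could not be tied to any single group. The new pair isolates one change: in this assay, putting hydrogen in place of chloro, at the carbon ortho to a chloro group and para to a large group, gives a 2.7-fold higher number from compound 2 to compound 3 (0.43 log units; beyond the scatter) and this counts as a modest step. This shows that this one position alone can move the number measurably, though only by a small part of the gap seen between the two earlier compounds, and nothing available here speaks to the reason for the step.

This single pair does not tell whether the chloro group that remains on compound 3 carries a similar weight, or what would happen to the number if it too gave way to hydrogen. It also leaves open how the number would respond if the position that lost its chloro carried a different group instead, such as an amine, a methoxy group or a carboxylic acid.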